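Moving the Imidazole Attachment Point from Compound 3 to Compound 4

This account rests on a few compounds, and the source may have more. Where it says the series, first, only, none or still open, it means among the compounds named here.

Compound 1 `CC(CC(=O)/N=C(\N)NCCCc1cccnc1)c1ccccc1` in an assay on isolated protein for antagonist activity at histamine H2 receptor (Cavia porcellus), with a stated time of 30 min (a lower number here means tighter binding, a higher number weaker binding), gives > 31600 nM, a limit of the assay rather than a number.
Compound 2 `CC(CC(=O)/N=C(\N)NCCCc1ccncc1)c1ccccc1` in this assay gives 19100 nM.
Compound 3 `CC(CC(=O)/N=C(\N)NCCCn1ccnc1)c1ccccc1` in this assay gives > 31600 nM, again a limit.

Compound 3 therefore stands at the limit of the assay (the limit of > 31600 nM in this assay, at which 2 of the 3 values shown sit). The two steps that end at that limit read an at least 1.6-fold higher number from compound 2 to compound 3 (0.21 log units; that floor lies within the scatter) and a step that the two limits leave unreadable from compound 1 to compound 3, and neither yields a number for it. Compound 4 `CC(CC(=O)/N=C(\N)NCCCc1ncc[nH]1)c1ccccc1` differs by 1H-imidazol-2-yl in place of 1H-imidazol-1-yl on a saturated chain carbon, three bonds along the chain from an amine nitrogen. Within the data shown here, none of the measured steps moves the attachment point of a ring, so no measured step bears directly on this change; the expected step is one that cannot be sized, and compound 4 is expected to remain near the limit, an at least 1.0-fold lower number from compound 3 to compound 4 (0.02 log units; that floor lies within the scatter). Compound 4 is estimated at 30000 nM, with a range from 8000 nM to 100000 nM.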

Compound 4, dissociation constant: 12600 nM
Compound 4: the middle estimate sits 2.4-fold (0.38 log units) above what was measured; low and high end bracket the measured number.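

In this assay, the attachment point of the imidazole ring matters at this place on the chain, since the same atoms joined differently give an at least 2.5-fold lower number from compound 3 to compound 4 (0.39 log units; beyond the scatter). 1H-imidazol-2-yl also separates from pyridin-3-yl, with an at least 2.5-fold lower number from compound 1 to compound 4 (0.39 log units; beyond the scatter), whereas a 1.5-fold lower number from compound 2 to compound 4 (0.18 log units; within the scatter) shows no separation from pyridin-4-yl. The entering group differs from the leaving one by carrying a hydrogen-bond donor, but these compounds cannot show whether that difference matters. Open, on these data alone, is whether a 1H-imidazol-4-yl ring or a longer chain would lower the number further. The full size of the two steps beyond the scatter also stays open, as each starts from a limit: the limit of > 31600 nM in this assay, at which 2 of the 4 values shown sit.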